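From Methyl to Carboxymethyl on the Nitrogen

The source may hold more compounds than are shown below. What is called first, only, known or untested is meant among the compounds shown, and "the series" means these compounds.

In a functional assay on MKN-45 cells (Homo sapiens) for inhibition, with a stated time of 72 h (a higher number here means a weaker inhibitor, a lower number a stronger inhibitor), compound 1 `COc1cc(C(=O)c2cccc3c2ccn3C)cc(OC)c1OC` gives 21.6 nM and compound 2 `COc1cc(C(=O)c2ccc3c(ccn3C)c2)cc(OC)c1OC` gives 11.2 nM. Within the data shown here, these two values lie within the scatter of each other, so compound 2 stands level with the only other measured compound. Compound 3 `COc1cc(C(=O)c2ccc3c(ccn3CC(=O)O)c2)cc(OC)c1OC` departs from compound 2 in one place: carboxy in place of hydrogen on a saturated chain carbon bound to an aromatic nitrogen, which turns methyl into carboxymethyl. Among the measured compounds shown here, no measured pair shows the effect of this change, so the expectation rests on the structural change alone. The expected step of a 36-fold higher number from compound 2 to compound 3 (1.55 log units; beyond the scatter) is large and toward weaker inhibition. For compound 3 the estimated value is 400 nM, with an expected range of 50 nM to 3000 nM.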

Compound 3, half-maximal inhibitory concentration: 396 nM
The estimate for compound 3 lay 1.0-fold (0.00 log units) above the measured number, and the stated range covers the measured number.
By their numbers in this assay, from the lowest: compounds 2 and 1 (each within the scatter of the next); then compound 3.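

Replacing methyl with carboxymethyl gives a 35-fold higher number from compound 2 to compound 3 (1.55 log units; beyond the scatter) in this assay and so marks a large loss of inhibition. Among these compounds, this is the first measured change at this position, and it shows that the nitrogen substituent of compound 2 cannot be exchanged freely without cost to the number. Nothing available explains the size of this step.

The compounds shown leave open whether the loss belongs to the carboxylic acid itself or to any larger group at this place. A methyl ester, a primary amide, an amine or a longer chain ending in a carboxylic acid could each bear on that question.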